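One group exchanged on a three-membered ring

A few compounds are considered here, and "the series" means these few. Any claim that something is new, unique, unknown or untested is made for them only; others in the source may bear on it.

- compound 1 `O=C(O)c1cncc(N2CC(O)(c3ccc(OCc4c(-c5c(Cl)cccc5Cl)noc4C4CC4)cc3Cl)C2)c1`: 197000 nM
- compound 2 `O=C(O)c1cccc(C2CC2c2ccc(OCc3c(-c4c(Cl)cccc4Cl)noc3C3CC3)cc2Cl)c1`: 20000 nM

In a physicochemical assay for solubility (on this read-out higher numbers stand for higher solubility and lower numbers for lower solubility), compound 2 gives 20000 nM, the lower of the two numbers, and the gap up to compound 1 lies beyond the usual scatter of repeat measurements. Compound 3 `CC(C)n1nc(C(=O)O)cc1C1CC1c1ccc(OCc2c(-c3c(Cl)cccc3Cl)noc2C2CC2)cc1Cl` has not yet been measured. It keeps the rest of compound 2 but carries 3-carboxy-1-isopropyl-1H-pyrazol-5-yl in place of 3-carboxyphenyl on a saturated ring carbon of a three-membered non-aromatic ring of carbon only (3-carboxy-1-isopropyl-1H-pyrazol-5-yl in place of 3-carboxyphenyl on a saturated ring carbon). Both groups carry a carboxy unit, so the exchange swaps the ring that holds it and adds an isopropyl group.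

For the measured compounds named here, compounds 1 and 2 differ in more than one place, so no measured pair shows what this exchange does, and any forecast here is uncertain. Going by the values given here, the only guide is that compound 1 reaches 197000 nM in this assay, so compound 2 does not mark the top of this small set. A modest rise, perhaps no larger than the scatter, is the expected result, an estimated step of a 1.8-fold higher number from compound 2 to compound 3 (0.24 log units; within the scatter). The estimate for compound 3 is 35000 nM, with an expected range from 12000 nM to 110000 nM.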

Compound 3, solubility: 158000 nM
Compound 3: the middle estimate sits 4.5-fold (0.65 log units) below what was measured; the measured number lies above the stated range.
By their numbers in this assay, from the lowest: compound 2; then compounds 3 and 1 (each within the scatter of the next).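

In this assay, for the compounds shown here, putting 3-carboxy-1-isopropyl-1H-pyrazol-5-yl in place of 3-carboxyphenyl on a saturated ring carbon of the three-membered ring gives a 7.9-fold higher number from compound 2 to compound 3 (0.90 log units; beyond the scatter), the only step here in which the compounds differ in a single place. Both groups carry a carboxy unit, so this position responds to a change in the ring holding that unit together with the added isopropyl group, and the step lies beyond the usual scatter of repeat measurements. No measurement here says what lies behind this step.

The ring and the isopropyl group change together, so the compounds shown leave open which of them accounts for the step; a 3-carboxy-1-methyl-1H-pyrazol-5-yl group, with methyl in place of isopropyl, would begin to separate the two. As far as these compounds go, it also remains open whether the higher number depends on the carboxy unit, a question that a primary amide at the same place on the pyrazole ring could address.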